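Methoxy in Place of Methyl: From Compound 2 to Compound 4

The source may report more compounds than this note shows. Statements on the series, on what has been measured and on what is new or still open speak of the compounds shown alone.

Compound 1 `COc1cccc2sc(NC(=O)c3ccc(C(F)(F)F)cc3)nc12`: > 10 ug/mL
Compound 2 `COc1ccc2sc(NC(=O)c3ccc(C)cc3)nc2c1`: > 10 ug/mL
Compound 3 `Cc1cc2nc(NC(=O)Nc3ccccc3C)sc2cc1C`: 0.18 ug/mL

In a functional assay on SK-HEP1 cells (Homo sapiens) for antiproliferative activity, read by sulforhodamine B assay (on this read-out lower numbers stand for stronger inhibition of growth and higher numbers for weaker inhibition of growth), compound 1 reports only a limit, > 10 ug/mL. Compound 2 likewise reports only a limit, > 10 ug/mL, so its standing among the three is known only as sitting at the limit of > 10 ug/mL in this assay, at which 2 of the 3 values shown sit. Compound 3 gives a number, 0.18 ug/mL.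

Compound 4 `COc1ccc(C(=O)Nc2nc3cc(OC)ccc3s2)cc1` differs from compound 2 by one change: methoxy in place of methyl on an aromatic carbon. For the measured compounds named here, no measured pair shows this change, so no step in this assay is known for it. The step from compound 2 to compound 4 is expected to be small, a step that the limit leaves unreadable from compound 2 to compound 4, within the scatter. Compound 4 is therefore estimated at 15 ug/mL, with a range from 4 ug/mL to 50 ug/mL, and most likely again only a limit.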

Compound 4, concentration for 50% growth inhibition: > 10 ug/mL
Compound 4 ended at the assay's limit; the forecaster's own chance of this, stated with the estimate: 75%; the middle value does not contradict the limit.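

For the compounds shown here, compound 4 and compound 2 both report only a limit, not a number, so no step between them can be read: the limit of > 10 ug/mL in this assay, at which 3 of the 4 values shown sit. The compounds shown leave open whether methoxy in place of methyl on an aromatic carbon changes the result in this assay.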